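The source may hold more compounds than are shown below. What is called first, only, known or untested is meant among the compounds shown, and "the series" means these compounds.

In a functional assay on CCRF-CEM cells (Homo sapiens) for cytotoxicity, in the presence of a further agent that is not named here (on this read-out lower numbers stand for stronger inhibition and higher numbers for weaker inhibition), compound 2 `COC(=O)c1ccc(CN(CCCc2c(N)nc(N)nc2O)c2cc(F)c(F)cc2[N+](=O)[O-])cc1` gives 53000 nM, the higher of the two real numbers, while compound 1 `CC(C)(C)OC(=O)CCC(Nc1ccc(CN(CCCc2c(N)nc(N)nc2O)c2ccc([N+](=O)[O-])c(F)c2[N+](=O)[O-])cc1)C(=O)OC(C)(C)C` gives 4000 nM. Compound 3 `Nc1nc(N)c(CCCN(Cc2ccc(NC(CCC(=O)O)C(=O)O)cc2)c2cc(F)c(F)cc2[N+](=O)[O-])c(O)n1` gives > 100000 nM, which is a limit of the assay and not a number. Compound 4 `COC(=O)c1ccc(CN(CCCc2c(N)nc(N)nc2O)c2cc(F)ccc2[N+](=O)[O-])cc1` carries hydrogen in place of fluoro on an aromatic carbon, turning 4,5-difluoro-2-nitrophenyl into 5-fluoro-2-nitrophenyl (hydrogen in place of fluoro on an aromatic carbon). Among the measured compounds shown here, the only measured step, an at least 1.8-fold higher number from compound 2 to compound 3 (0.27 log units; that floor lies within the scatter), replaces methoxycarbonyl and leaves this fluoro untouched, so it offers no size to carry over. No change beyond the scatter is therefore expected in this assay, and the estimated step is a 1.1-fold lower number from compound 2 to compound 4 (0.03 log units; within the scatter). For compound 4 the expected value is 50000 nM, with an estimated range of 18000 nM to 100000 nM.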

Compound 4, half-maximal inhibitory concentration: 30000 nM
Compound 4: the middle estimate sits 1.7-fold (0.22 log units) above what was measured, within the range that was stated.
By their numbers in this assay, from the lowest: compound 1; then compounds 4 and 2 (each within the scatter of the next). At a limit, above all of these: compound 3.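

Hydrogen in place of the fluoro that sits para to a large group gives a 1.8-fold lower number from compound 2 to compound 4 (0.25 log units; within the scatter), so in this assay losing this one atom leaves no change that can be told from scatter. Among the compounds shown here, the earlier step touched only the methoxycarbonyl, so this is the first reading at this position, and it shows this fluoro is not needed for the weak activity of compound 2. These numbers also lie in the upper part of the read-out, which has a ceiling: the limit of > 100000 nM in this assay, at which 1 of the 4 values shown sits.

Going by these compounds, whether an amine or a methoxy group at this position would move the number stays open. So does the effect of the same swap in a compound carrying (1,3-dicarboxypropyl)amino instead of methoxycarbonyl.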